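The source may report more compounds than this note shows. Statements on the series, on what has been measured and on what is new or still open speak of the compounds shown alone.

Notes on the series, with the group on the carbonyl carbon varied on a shared core. In a functional assay on SK-BR-3 cells (Homo sapiens) for antiproliferative activity, read by XTT assay, with a stated time of 72 h (a higher number here means a weaker inhibitor, a lower number a stronger inhibitor), compound 1 `COc1ccc(-c2cc3ccccc3nc2/C=C/C(=O)c2ccc(F)cc2)cc1` gives 810 nM as the lowest number, compound 2 `COc1ccc(-c2cc3ccccc3nc2/C=C/C(=O)c2c(OC)cccc2OC)cc1` gives 3830 nM as the middle one, and compound 3 `COc1ccc(-c2cc3ccccc3nc2/C=C/C(=O)c2ccc(N)cc2)cc1` gives 8560 nM as the highest.

Compound 4 `COc1ccc(-c2cc3ccccc3nc2/C=C/C(=O)c2ccsc2)cc1` is still unmeasured. It carries thiophen-3-yl in place of 2,6-dimethoxyphenyl on a carbonyl carbon, counted as thiophen-3-yl in place of 2,6-dimethoxyphenyl on a carbonyl carbon here.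

Two measured steps change this same place with compound 2 at one end. The first is a 4.7-fold higher number from compound 1 to compound 2 (0.67 log units; beyond the scatter) and the second is a 2.2-fold higher number from compound 2 to compound 3 (0.35 log units; beyond the scatter) in size. Both are modest and beyond the scatter, and they show that leaving 2,6-dimethoxyphenyl can move the number either way. The wider span, an 11-fold higher number from compound 1 to compound 3 (1.02 log units; beyond the scatter) overall, is large.

Among the compounds with values here, no measured compound holds thiophen-3-yl, so the direction is only tentative. A modest move to a lower number in this assay is expected, namely a 2.6-fold lower number from compound 2 to compound 4 (0.41 log units; beyond the scatter) as the estimated step. For compound 4 the estimate is 1500 nM within an expected range of 450 nM to 4500 nM as the likely bounds.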

Compound 4, half-maximal inhibitory concentration: 660 nM
For compound 4 the middle estimate is 2.3-fold (0.36 log units) above the measured one; the measured number falls inside the stated range.
By their numbers in this assay, from the lowest: compounds 4 and 1 (each within the scatter of the next); then compound 2; then compound 3.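

In this assay the carbonyl carbon also accepts a five-membered aromatic ring with 1 hetero atom, and the six-membered aromatic ring of carbon only is not needed for the lowest numbers shown: thiophen-3-yl and 4-fluorophenyl cannot be told apart, with a 1.2-fold lower number from compound 1 to compound 4 (0.09 log units; within the scatter). Moving away from the two weaker groups gives a 5.8-fold lower number from compound 2 to compound 4 (0.76 log units; beyond the scatter) and the large 13-fold lower number from compound 3 to compound 4 (1.11 log units; beyond the scatter), so this change reaches the low end of the series rather than an intermediate level. No supporting data bear on this result.

The compounds shown leave open whether a furan ring, a pyridine ring or a saturated ring such as cyclohexyl would give a similar number on the carbonyl carbon. As far as these compounds go, whether the sulfur atom itself matters, rather than the ring as a whole, also remains open.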